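Swapping a Pyridinylmethyl Arm for Tolyl on Compound 2

This account rests on a few compounds, and the source may have more. Where it says the series, first, only, none or still open, it means among the compounds named here.

Compound 2 `Nc1ccccc1NC(=O)c1ccc(CSC(=S)N2CCN(Cc3ccncc3)CC2)cc1` stands second highest of the three numbers measured in a functional assay on HeLa cells (Homo sapiens) for antiproliferative activity, read by CCK-8 assay, with a stated time of 72 h, tested at 2 uM; on this read-out higher numbers stand for a stronger effect at the one concentration tested and lower numbers for a weaker effect: compound 2 gives 59.5%, close to compound 1 `CCN(Cc1ccncc1)C(=S)SCc1ccc(C(=O)Nc2ccccc2N)cc1`, which gives 63.5%, while compound 3 `Nc1ccccc1NC(=O)c1ccc(CSC(=S)N2CCc3cc(Cl)ccc32)cc1` gives 40.1%, a gap that lies beyond the scatter. Compound 4 `Cc1ccc(N2CCN(C(=S)SCc3ccc(C(=O)Nc4ccccc4N)cc3)CC2)cc1` differs from compound 2 by 4-methylphenyl in place of (pyridin-4-yl)methyl on an amine nitrogen in a ring. Among the compounds with values here, no measured step covers this exact change. Within the data shown here, the only recorded step, a number 23.4 percentage points lower from compound 1 to compound 3 (beyond the scatter), replaced the whole amine on the thiocarbonyl carbon, a larger alteration, so it bears on compound 4 only loosely. Both carriers of the (pyridin-4-yl)methyl group, compounds 1 and 2, stand above compound 3 with its 40.1%. A modest decline is therefore expected, a number 9.5 percentage points lower from compound 2 to compound 4 (within the scatter). Compound 4 is estimated at 50%, within 32% to 68%.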

Compound 4, a percentage reported as inhibition, at one concentration (the size of the read-out at that concentration, not a potency): 25.3%
For compound 4 the middle estimate is 24.7 percentage points above the measured one; measured number below the stated range.
By their numbers in this assay, from the lowest: compound 4; then compound 3; then compounds 2 and 1 (each within the scatter of the next).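

In this assay, within the data shown here, the 4-methylphenyl for (pyridin-4-yl)methyl exchange gives a number 34.2 percentage points lower from compound 2 to compound 4 (beyond the scatter) at a position the earlier compounds left unchanged. The read-out on this amine nitrogen in a ring therefore depends strongly on which of two aromatic groups of equal heavy-atom count sits there, although this rests on one pair. Nothing shown here accounts for the drop.

The change replaces the ring nitrogen and the one-carbon link together, leaving their separate contributions unresolved. As far as these compounds go, it remains open how a plain benzyl group or a pyridin-4-yl group attached directly would compare.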